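Oxadiazole methyl-to-phenyl exchange on a second core

The source may hold more compounds than are shown below. What is called first, only, known or untested is meant among the compounds shown, and "the series" means these compounds.

Two cores carry the same five-membered ring. Compound 1 `C=C(C)C(=O)c1ccc(OCc2nc(C)no2)c(C)c1C` and compound 2 `C=C(C)C(=O)c1ccc(OCc2nc(-c3ccccc3)no2)c(C)c1C` share the first core; compound 3 `C=C(C)C(=O)c1ccc(OCc2nc(C)no2)cc1Cl` and compound 4 `C=C(C)C(=O)c1ccc(OCc2nc(-c3ccccc3)no2)cc1Cl` share the second. How the two cores differ is not broken down here.

In an assay on HL-60 cells for inhibition of glutathione S-transferase P (Homo sapiens) (a higher number here means a weaker inhibitor, a lower number a stronger inhibitor), compound 1 gives 4000 nM, and compound 2 gives 1800 nM. The change between them is phenyl in place of methyl on an aromatic carbon and it brings a 2.2-fold lower number from compound 1 to compound 2 (0.35 log units; beyond the scatter). Compound 3, measured in this assay, gives 2100 nM; set against compound 2 the two numbers lie within the usual scatter, and against compound 1 they also lie within it, so no order among these three is claimed beyond the single counted step.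

Compound 4 has not yet been measured in this assay. It differs from compound 3 by phenyl in place of methyl on an aromatic carbon. The place lines of the two changes are the same word for word, so this is the same kind of change as the one from compound 1 to compound 2, made once on each core; it occurs two times in all among the compounds shown.

For the measured compounds named here, with only one earlier instance of the change, the expectation for compound 4 rests on that step alone. Going by the values given here, the step from compound 3 to compound 4 is expected to come out as a 2.1-fold lower number from compound 3 to compound 4 (0.32 log units; beyond the scatter), close to the earlier one, because a 2.2-fold lower number from compound 1 to compound 2 (0.35 log units; beyond the scatter) is the only measured precedent. Compound 4 is thus estimated at 1000 nM, with a range from 450 nM to 2200 nM to allow for the scatter and for the core being different.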

Compound 4, half-maximal inhibitory concentration: 600 nM
For compound 4 the middle estimate is 1.7-fold (0.22 log units) above the measured one; the range from low to high includes it.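

In this assay, phenyl in place of methyl on an aromatic carbon gives a 3.5-fold lower number from compound 3 to compound 4 (0.54 log units; beyond the scatter), so the exchange lowers the number on the core of compound 3 as it does on the core of compound 1. The two steps point the same way, and the gap in their size gives no ground for treating the second as larger, so in this series the change carries over from one core to the other without a readable difference: the same change on two cores in this assay, a 2.2-fold lower number (0.35 log units; beyond the scatter) from compound 1 to compound 2 and a 3.5-fold lower number (0.54 log units; beyond the scatter) from compound 3 to compound 4, 1.6-fold (0.20 log units) apart, within the scatter of two such steps. This rests on one matched pair per core: it supports no general rule for other cores, and it does not show why the exchange lowers the number or which feature of the phenyl group is responsible.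

From the compounds shown here alone, only methyl and phenyl appear at this carbon of the five-membered aromatic ring, so it remains open whether the trend follows the number of heavy atoms, the presence of an aromatic ring or something else, and an amine, a carboxylic acid or a longer chain at the same place would help to separate these. Also open is how far the exchange would hold on cores other than the two shown.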